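The source may report more compounds than this note shows. Statements on the series, on what has been measured and on what is new or still open speak of the compounds shown alone.

Of the compounds shown here, two have been measured in a functional assay on Molt4/C8 cells (Homo sapiens) for cytotoxicity; a lower number here means a stronger inhibitor, a higher number a weaker inhibitor. Compound 1 `O=C(/C=C/C(=O)N1C/C(=C\c2ccc([N+](=O)[O-])cc2)C(=O)/C(=C/c2ccc([N+](=O)[O-])cc2)C1)Nc1ccc(Cl)c(Cl)c1` gives 600 nM in this assay, the lower of the two numbers. Compound 2 `CC(=O)c1ccc(NC(=O)/C=C/C(=O)N2C/C(=C\c3ccccc3)C(=O)/C(=C/c3ccccc3)C2)cc1` differs from compound 1 in several places; in this assay compound 2 gives 1400 nM, and that gap lies beyond the scatter. Compound 3 `Cc1ccc(NC(=O)/C=C/C(=O)N2C/C(=C\c3ccc([N+](=O)[O-])cc3)C(=O)/C(=C/c3ccc([N+](=O)[O-])cc3)C2)cc1C` has not been measured yet; it differs from compound 1 by 3,4-dimethylphenyl in place of 3,4-dichlorophenyl on an amide-type nitrogen. Within the data shown here, no measured pair shows this exchange, so only a modest step, if any, is expected, leaning toward a weaker inhibitor: a 1.5-fold higher number from compound 1 to compound 3 (0.18 log units; within the scatter). Compound 3 is therefore estimated at 900 nM in this assay, within a range of 350 nM to 2500 nM.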

Compound 3, half-maximal inhibitory concentration: 660 nM
For compound 3 the middle estimate is 1.4-fold (0.13 log units) above the measured one; low and high end bracket the measured number.
By their numbers in this assay, from the lowest: compounds 1 and 3 (each within the scatter of the next); then compound 2.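

In this assay, among these compounds, 3,4-dimethylphenyl in place of 3,4-dichlorophenyl on the amide-type nitrogen gives a 1.1-fold higher number from compound 1 to compound 3 (0.04 log units; within the scatter), so this is the first direct comparison at this position. Here, two chlorine atoms can be exchanged for two methyl groups with no readable change in the number. No accompanying measurement bears on this result.

Going by these compounds, whether an unsubstituted phenyl, or a phenyl carrying an amine or a carboxylic acid, would give a similar number remains open. So does whether this exchange behaves the same way on a different core.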